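This account rests on a few compounds, and the source may have more. Where it says the series, first, only, none or still open, it means among the compounds named here.

Compound 2 `C=C1CC[C@H]2[C@@](C)(CC[C@@H](OC(=O)c3ccccc3)[C@@]2(C)NC=O)[C@@H]1/C=C/C1=CCOC1=O` stands only at a limit: in an assay for inhibition of hexokinase-2 (Homo sapiens), read by coupled enzyme assay, with a stated time of 10 min, in the presence of a further agent that is not named here (a higher number here means a weaker inhibitor, a lower number a stronger inhibitor), compound 2 gives > 50000 nM, which is a limit of the assay and not a number. Compound 1 `C=C1CC[C@H]2[C@@](C)(CC[C@@H](OC(=O)c3cccnc3)[C@@]2(C)NC=O)[C@@H]1/C=C/C1=CCOC1=O` likewise reaches only a limit in this assay, > 50000 nM. The step that the two limits leave unreadable from compound 1 to compound 2 is therefore unreadable, as the limit of > 50000 nM in this assay, at which 2 of the 2 values shown sit, shows. Compound 3 `C=C1CC[C@H]2[C@@](C)(CC[C@@H](OC(=O)[C@H](N)CC(C)C)[C@@]2(C)NC=O)[C@@H]1/C=C/C1=CCOC1=O` carries 1-amino-3-methylbutyl in place of phenyl on a carbonyl carbon. No readable measured step bears on this change, so no direction can be drawn from the series. For compound 3 the expected value in this assay is 50000 nM, with a range from 10000 nM to 100000 nM. The step of a number no higher from compound 2 to compound 3 (the limit leaves the size open) is thus expected to remain at the limit.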

Compound 3, half-maximal inhibitory concentration: > 50000 nM
Compound 3 was reported as a limit (the forecaster's own chance of this, stated with the estimate: 75%); the middle value sits exactly at the limit.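

No step can be read among compound 1, compound 2 and compound 3, because their values give only a limit of the assay: the limit of > 50000 nM in this assay, at which 3 of the 3 values shown sit.

Going by these compounds, whether any group on this carbonyl carbon gives a readable value in this assay remains open.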